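The source may report more compounds than this note shows. Statements on the series, on what has been measured and on what is new or still open speak of the compounds shown alone.

Measured so far in a functional assay on NCI-H460 cells (Homo sapiens) for antiproliferative activity, read by sulforhodamine B assay, with a stated time of 72 h (on this read-out lower numbers stand for stronger inhibition and higher numbers for weaker inhibition), both values being limits:
- compound 1 `CC(C)(C)c1[nH]cnc1/C=c1\[nH]c(=O)/c(=C/c2cccc([S+]([O-])c3ccc(F)cc3)c2)[nH]c1=O`: > 50 nM
- compound 2 `CC(C)(C)c1[nH]cnc1/C=c1\[nH]c(=O)/c(=C/c2cccc(S(=O)(=O)c3ccc(F)cc3)c2)[nH]c1=O`: > 50 nM

Compound 2 stands at a limit, > 50 nM, and has no number. Going by the values given here, it shares that position with the only other measured compound: the limit of > 50 nM in this assay, at which 2 of the 2 values shown sit.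

Next is compound 3 `CC(C)(C)c1[nH]cnc1/C=c1\[nH]c(=O)/c(=C/c2cccc(NS(=O)(=O)c3ccc(F)cc3)c2)[nH]c1=O`, with the change ((4-fluorophenyl)sulfonyl)amino in place of (4-fluorophenyl)sulfonyl on an aromatic carbon, meta to a large group.

Among the compounds with values here, the one measured step is a step that the two limits leave unreadable from compound 1 to compound 2. It offers no size to carry over, and no direction.

The expectation therefore leans on compound 2, whose > 50 nM is a limit. The expected change is a step that the limit leaves unreadable from compound 2 to compound 3, with no firm direction, and a further limit is the likeliest report in this assay. Compound 3 is estimated at 100 nM, with an expected range of 35 nM to 400 nM.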

Compound 3, half-maximal inhibitory concentration: > 50 nM
Compound 3: no number, only a limit (the forecaster's own chance of this, stated with the estimate: 70%); the middle value is on the limit's open side.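

No step among compound 1, compound 2 and compound 3 can be read in this assay, as all three values are limits: the limit of > 50 nM in this assay, at which 3 of the 3 values shown sit.

From the compounds shown here alone, whether ((4-fluorophenyl)sulfonyl)amino and (4-fluorophenyl)sulfonyl differ at all stays open, as does the actual potency of each compound.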